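Fluorine Placed on a Different Phenyl Ring of Compound 1

A few compounds are considered here, and "the series" means these few. Any claim that something is new, unique, unknown or untested is made for them only; others in the source may bear on it.

Compound 1 `O=C(NOCc1ccccc1)c1cn(-c2ccccc2)nc1-c1ccccc1`: 122000 nM
Compound 2 `O=C(NOCc1ccccc1F)c1cn(-c2ccccc2)nc1-c1ccccc1`: 75700 nM

In an ADME assay on HEK-293T cells (Homo sapiens) for antiproliferative activity, read by MTT assay, with a stated time of 48 h, in the presence of a further agent that is not named here (on this read-out higher numbers stand for lower toxicity in this test and lower numbers for higher toxicity in this test), compound 1 gives 122000 nM, the highest of the two numbers. Compound 2 gives 75700 nM, and the step of a 1.6-fold lower number from compound 1 to compound 2 (0.21 log units; within the scatter) lies within the scatter. Compound 3 `O=C(NOCc1ccccc1)c1cn(-c2ccccc2)nc1-c1ccc(F)cc1` differs from compound 1 by fluoro in place of hydrogen on an aromatic carbon; cut one bond further out, this reads phenyl to 4-fluorophenyl. Among the measured compounds shown here, the only step at hand, a 1.6-fold lower number from compound 1 to compound 2 (0.21 log units; within the scatter), adds a fluoro at another place and stays within the scatter, so no step beyond the scatter is expected for compound 3, a 1.2-fold lower number from compound 1 to compound 3 (0.09 log units; within the scatter). Compound 3 is estimated at 100000 nM, ranging from 50000 nM to 200000 nM.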

Compound 3, half-maximal cytotoxic concentration: 217000 nM
For compound 3 the middle estimate is 2.2-fold (0.34 log units) below the measured one; the measured number lies above the stated range.
By their numbers in this assay, from the lowest: compounds 2, 1 and 3 (each within the scatter of the next, the first and the last beyond it).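

In this assay, phenyl to 4-fluorophenyl gives a 1.8-fold higher number from compound 1 to compound 3 (0.25 log units; within the scatter), so a fluoro at this second place also leaves the number within the scatter of compound 1. Set beside a 1.6-fold lower number from compound 1 to compound 2 (0.21 log units; within the scatter), the two fluoro steps have opposite signs, yet neither can be told apart from repeat scatter. No measurement shown here accounts for either step. The compounds shown leave open whether a larger or charged group at this place, such as an amine or a carboxylic acid, would give a step beyond the scatter.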